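Cyclopropylmethyl in place of the fluorobenzyl arm

This account rests on a few compounds, and the source may have more. Where it says the series, first, only, none or still open, it means among the compounds named here.

Compound 1 `O=C(O)c1ccccc1-c1ccc(CCc2ncc(Cc3ccccc3F)[nH]2)cc1`: 9.5 nM
Compound 2 `CCCCc1cnc(C(Cc2ccc(-c3ccccc3C(=O)O)cc2)C(C)C)[nH]1`: 2240 nM
Compound 3 `CCC(C)(C)Cc1c[nH]c(CCc2ccc(-c3ccccc3C(=O)O)cc2)n1`: 9.6 nM

In an in vitro functional assay on cells for agonist activity at Bombesin receptor subtype-3 (Mus musculus), read by luminescence and calcium flux (a higher number here means that more compound is needed for the effect, a lower number that less compound is needed), compound 1 gives the lowest number of the three, with compound 3 inside the scatter of it and compound 2 far beyond it. Compound 4 `O=C(O)c1ccccc1-c1ccc(CCc2ncc(CC3CC3)[nH]2)cc1` differs from compound 1 in one place: cyclopropyl in place of 2-fluorophenyl on a saturated chain carbon bound to an aromatic carbon. Going by the values given here, no measured pair isolates this change. Compound 3 shows that a branched saturated group in this place gives a number within the scatter of compound 1, yet the group that enters here is smaller than either, so a modest rise is expected, with a step of a 4.2-fold higher number from compound 1 to compound 4 (0.62 log units; beyond the scatter) that may or may not clear the scatter. Compound 4 is therefore estimated at 40 nM, between 8 nM and 200 nM.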

Compound 4, half-maximal effective concentration: 72 nM
For compound 4 the middle estimate is 1.8-fold (0.26 log units) below the measured one, and the stated range covers the measured number.
By their numbers in this assay, from the lowest: compounds 1 and 3 (each within the scatter of the next); then compound 4; then compound 2.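

In this assay, cyclopropyl in place of 2-fluorophenyl on a saturated chain carbon bound to an aromatic carbon gives a 7.6-fold higher number from compound 1 to compound 4 (0.88 log units; beyond the scatter) and so shows that this place responds to the exchange. Going by these compounds alone, this is the first pair that isolates a change here, and the step lies beyond the scatter. No measurement at hand accounts for it.

The compounds shown leave open whether a plain phenyl or a cyclohexyl on the same chain carbon would stand nearer compound 1 or compound 4. They therefore cannot separate the part of the fluorine from that of the ring.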